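The source may hold more compounds than are shown below. What is called first, only, known or untested is meant among the compounds shown, and "the series" means these compounds.

Compound 1, `Cc1n[nH]c2ccc(-c3nc4cnc(N5CCN(C)CC5)cn4c3Nc3cccc(Cl)c3)cc12`: 0%
Compound 2, `Cc1n[nH]c2ccc(-c3nc4cnc(N5CCN(C)CC5)cn4c3Nc3ccc(Br)cc3)cc12`: 83%
Compound 3, `Cc1n[nH]c2ccc(-c3nc4cnc(N5CCN(C)CC5)cn4c3Nc3ccc(I)cc3)cc12`: 0%

In a functional assay on MV4-11 cells (Homo sapiens) for inhibition, with a stated time of 120 h, tested at 10 uM (a lower number here means less inhibition, a higher number more inhibition at the concentration tested (going by the name of the read-out)), compound 1 gives 0%, level with compound 3 and the lowest of the three numbers, far from compound 2. The unmeasured compound 4, `Cc1n[nH]c2ccc(-c3nc4cnc(N5CCN(C)CC5)cn4c3Nc3ccc(Cl)cc3F)cc12`, differs from compound 1 in one place: 4-chloro-2-fluorophenyl in place of 3-chlorophenyl on a nitrogen on an aromatic ring.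

Two measured steps start from compound 1 and also exchange the halogen pattern on the phenyl ring on that nitrogen. The change to a 4-bromophenyl gave a number 83 percentage points higher from compound 1 to compound 2 (beyond the scatter), whereas the change to a 4-iodophenyl gave no change at the digits printed from compound 1 to compound 3 (within the scatter); between the two 4-halophenyl compounds the step was a number 83 percentage points lower from compound 2 to compound 3 (beyond the scatter). The 4-chloro-2-fluorophenyl of compound 4 is not covered by any measured compound, and the two comparable steps point in opposite directions. Compound 4 is therefore expected to show a modest rise, a number 30 percentage points higher from compound 1 to compound 4 (beyond the scatter), with a wide margin. The estimate for compound 4 is 30%, between 0% and 80%.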

Compound 4, a percentage reported as inhibition, at one concentration (the size of the read-out at that concentration, not a potency): 0%
Estimate against measurement, compound 4: 30 percentage points above; low and high end bracket the measured number.
By their numbers in this assay, from the lowest: compounds 1, 3 and 4 (each within the scatter of the next); then compound 2.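

In this assay the 4-chloro-2-fluorophenyl group gave no change at the digits printed from compound 1 to compound 4 (within the scatter) and no change at the digits printed from compound 3 to compound 4 (within the scatter), but a number 83 percentage points lower from compound 2 to compound 4 (beyond the scatter). Among the four groups now seen on this nitrogen, only the 4-bromophenyl of compound 2 stands apart, and a ring carrying both chlorine and fluorine joins the 3-chlorophenyl and the 4-iodophenyl rather than compound 2. Nothing available explains why these closely related halogenated rings separate in this way.

The compounds shown leave open how an unsubstituted phenyl, a 4-chlorophenyl without the fluorine or a 4-methoxyphenyl would read in this assay. As far as these compounds go, it therefore remains open whether the 4-bromophenyl is a lone exception or part of a wider set of groups at this place.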